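The source may hold more compounds than are shown below. What is called first, only, known or untested is meant among the compounds shown, and "the series" means these compounds.

Measured so far:
compound 1 `Cc1ccccc1C(=O)N(C(=S)OCCN1C(=O)c2ccccc2C1=O)c1ccc(Cl)cc1`: 21000 nM
compound 2 `O=C1c2ccccc2C(=O)N1CCOC(=S)N(C(=O)c1ccccc1[N+](=O)[O-])c1ccc(Cl)cc1`: 21000 nM
compound 3 `Cc1ccc(N(C(=O)c2ccccc2C)C(=S)OCCN2C(=O)c3ccccc3C2=O)cc1`: > 100000 nM (a limit, not a number)

In an ADME assay on MT4 cells (Homo sapiens) for cytotoxicity, read by MTT assay (on this read-out lower numbers stand for higher toxicity in this test and higher numbers for lower toxicity in this test), compound 3 stands at > 100000 nM, which is a limit of the measurement. Compound 4 `Cc1ccc(N(C(=O)c2ccccc2[N+](=O)[O-])C(=S)OCCN2C(=O)c3ccccc3C2=O)cc1` carries nitro in place of methyl on an aromatic carbon, ortho to a large group: nitro in place of methyl on an aromatic carbon. Among the measured compounds shown here, the one measured precedent for this exchange is no change at the digits printed from compound 1 to compound 2 (within the scatter). The other measured step, an at least 4.7-fold higher number from compound 1 to compound 3 (0.67 log units; beyond the scatter), concerns a different place, so it does not speak to this exchange directly. On the precedent alone, no change beyond the scatter is expected in this assay. The expected step is a number no higher from compound 3 to compound 4 (the limit leaves the size open). For compound 4 the estimated value is 100000 nM, with an expected range from 40000 nM to 200000 nM.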

Compound 4, half-maximal cytotoxic concentration: 100000 nM
Estimate against measurement, compound 4: no gap at the digits printed, within the range that was stated.
By their numbers in this assay, from the lowest: compounds 1 and 2 (each within the scatter of the next); then compound 4.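

In this assay, methyl in place of chloro now has a step of readable size, a 4.8-fold higher number from compound 2 to compound 4 (0.68 log units; beyond the scatter), whereas the earlier step rested on a limit. The change now stands on two cores: the same change on two cores in this assay, an at least 4.7-fold higher number (0.67 log units; beyond the scatter) from compound 1 to compound 3 and a 4.8-fold higher number (0.68 log units; beyond the scatter) from compound 2 to compound 4; the limit leaves it open whether they differ. Compound 3 stands at > 100000 nM, which is a limit and not a number. Nitro in place of methyl gives a number no higher from compound 3 to compound 4 (the limit leaves the size open), so the size of this step cannot be read.

Still open, from the compounds shown here alone, is how an amine or a carboxylic acid on this aromatic carbon, ortho to a large group, would compare with 2-methylphenyl and 2-nitrophenyl. A bromo or methoxy group in place of the chloro or methyl is equally untested by the compounds shown.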